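Thiophen-2-yl in place of phenyl on a sulfonyl sulfur

A few compounds are considered here, and "the series" means these few. Any claim that something is new, unique, unknown or untested is made for them only; others in the source may bear on it.

Measured in a functional assay on A549 cells (Homo sapiens) for inhibition, read by sulforhodamine B assay, with a stated time of 74 h; on this read-out higher numbers stand for weaker inhibition and lower numbers for stronger inhibition:
Compound 1 `O=C1C=CC2(C=C1)OCC(=O)N2S(=O)(=O)c1ccccc1`: > 10000 nM
Compound 2 `O=C1C=CC2(C=C1)OCC(=O)N2S(=O)(=O)c1ccccc1OC(F)(F)F`: > 10000 nM
Compound 3 `O=C1C=CC2(C=C1)OCC(=O)N2S(=O)(=O)c1ccccc1C(F)(F)F`: > 10000 nM

Compound 1 stands at > 10000 nM, which is a limit and not a number. Compound 2 gives > 10000 nM, also a limit. Compound 3 gives > 10000 nM, again a limit. The whole picture so far comes down to one mark: the limit of > 10000 nM in this assay, at which 3 of the 3 values shown sit.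

Compound 4 `O=C1C=CC2(C=C1)OCC(=O)N2S(=O)(=O)c1cccs1` keeps the core of compound 1 and carries thiophen-2-yl in place of phenyl on a sulfonyl sulfur. Going by the values given here, two measured steps bear on this only loosely, as each is a replacement on an aromatic carbon and not an exchange of the whole ring: a step that the two limits leave unreadable from compound 1 to compound 2 and a step that the two limits leave unreadable from compound 1 to compound 3. Neither has a readable size, and neither sets a direction.

The expectation therefore rests on compound 1 at > 10000 nM and on (the limit of > 10000 nM in this assay, at which 3 of the 3 values shown sit). No step beyond the scatter is expected in this assay, in either direction, and the likeliest outcome is that compound 4 also reports only a limit. The estimated step is a step that the limit leaves unreadable from compound 1 to compound 4. For compound 4 the estimate is 15000 nM, with an expected range from 5000 nM to 40000 nM.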

Compound 4, half-maximal inhibitory concentration: > 10000 nM
Compound 4 gave a limit, no number; the forecaster's own chance of this, stated with the estimate: 75%; the middle value is on the limit's open side.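

Compound 4, like compound 1, reports only a limit, so the exchange of phenyl for thiophen-2-yl on the sulfonyl sulfur yields no readable step. All the results shown rest on a single mark: the limit of > 10000 nM in this assay, at which 4 of the 4 values shown sit.

The compounds shown leave open whether any group on the sulfonyl sulfur of the shared core would give a measurable value in this assay.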